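From benzyl to 4-methylbenzyl: compound 3 to compound 4

A few compounds are considered here, and "the series" means these few. Any claim that something is new, unique, unknown or untested is made for them only; others in the source may bear on it.

In a functional assay on HepG2 cells (Homo sapiens) for inhibition, read by MTT assay, with a stated time of 48 h (a lower number here means a stronger inhibitor, a higher number a weaker inhibitor), compound 1 `COc1ccc(-n2c(S)nnc2-c2cc(OC)c(OC)c(OC)c2)cc1`, with hydrogen on the sulfur, gives 57500 nM.

Compound 2 `COc1ccc(-n2c(SC)nnc2-c2cc(OC)c(OC)c(OC)c2)cc1`, with methyl on the sulfur, reads > 60000 nM, which is a limit.

Compound 3 `COc1ccc(-n2c(SCc3ccccc3)nnc2-c2cc(OC)c(OC)c(OC)c2)cc1`, with benzyl on the sulfur, reads > 60000 nM, also a limit.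

Compound 3 therefore has no number of its own and stands at the limit of > 60000 nM in this assay, at which 2 of the 3 values shown sit.

Substitution on the sulfur gives an at least 1.0-fold higher number from compound 1 to compound 2 (0.01 log units; that floor lies within the scatter) and an at least 1.0-fold higher number from compound 1 to compound 3 (0.01 log units; that floor lies within the scatter). Extending methyl to benzyl gives a step that the two limits leave unreadable from compound 2 to compound 3.

Compound 4 `COc1ccc(-n2c(SCc3ccc(C)cc3)nnc2-c2cc(OC)c(OC)c(OC)c2)cc1` carries methyl in place of hydrogen on an aromatic carbon, turning benzyl into 4-methylbenzyl. For the measured compounds named here, none of the measured steps touches that ring, and those nearest to it show only floors within the scatter or no readable size. No step beyond the scatter is therefore expected in this assay, and no direction is favoured. A further report as a limit is the likely outcome.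

The estimate corresponds to an expected step that the limit leaves unreadable from compound 3 to compound 4.

Compound 4 is expected near 80000 nM, with an estimated range of 40000 nM to 200000 nM.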

Compound 4, half-maximal inhibitory concentration: 31600 nM
The estimate for compound 4 lay 2.5-fold (0.40 log units) above the measured number; measured number below the stated range.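

In this assay, 4-methylbenzyl gives compound 4 a number of its own, the only one among the sulfur-substituted compounds, whereas compound 2 and compound 3 stay at a limit: the limit of > 60000 nM in this assay, at which 2 of the 4 values shown sit.

The methyl on the aromatic carbon reads as an at least 1.8-fold lower number from compound 3 to compound 4 (0.27 log units; that floor lies within the scatter), and the comparison with methyl on the sulfur reads as an at least 1.8-fold lower number from compound 2 to compound 4 (0.27 log units; that floor lies within the scatter), so neither floor establishes a real change. Against hydrogen on the sulfur, the result is a 1.8-fold lower number from compound 1 to compound 4 (0.26 log units; within the scatter), which shows that a substituted benzyl on the sulfur can keep a measurable value in this series.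

The true distance between compound 3 and compound 4 remains unresolved. Also open, from the compounds shown here alone, is how an amine or a carboxylic acid in place of that methyl would read.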